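Shortening an Ether Chain on an Inactive Scaffold

This account rests on a few compounds, and the source may have more. Where it says the series, first, only, none or still open, it means among the compounds named here.

Compound 1 `CCOC(=O)[C@@H]1C[C@@]23CN(C)C[C@@H](CCC4=C2[C@@H]1CC4=O)C31CC[C@](CC)(OC)OC1` and compound 2 `CCO[C@@]1(CC)CCC2(CO1)[C@@H]1CCC3=C4[C@H](CC3=O)[C@H](C(=O)OC)C[C@@]42CN(C)C1` share a core and were both tested in a functional assay on SMMC-7721 cells (Homo sapiens) for cytotoxicity, read by MTT assay, with a stated time of 48 h; a lower number here means a stronger inhibitor, a higher number a weaker inhibitor. In this assay compound 1 gives only a limit, > 40000 nM. In this assay compound 2 also gives only a limit, > 40000 nM. Both measured values sit at the limit of > 40000 nM in this assay, at which 2 of the 2 values shown sit. Compound 3 `CC[C@]1(OC)CCC2(CO1)[C@@H]1CCC3=C4[C@H](CC3=O)[C@H](C(=O)OC)C[C@@]42CN(C)C1` differs from compound 2 in one place: hydrogen in place of methyl on a saturated chain carbon bound to an oxygen on a saturated carbon. Among the measured compounds shown here, no measured step covers a change of this kind here. The expected step that the limit leaves unreadable from compound 2 to compound 3 is none beyond the scatter. Compound 3 is therefore expected to give about 60000 nM, within 30000 nM to 200000 nM, and most likely again only a limit.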

Compound 3, half-maximal inhibitory concentration: > 40000 nM
Compound 3: only a limit was reported; the forecaster's own chance of this, stated with the estimate: 85%; the middle value is on the limit's open side.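

In this assay, among the compounds shown here, no step between compound 1, compound 2 and compound 3 can be read, since each gives only a limit: the limit of > 40000 nM in this assay, at which 3 of the 3 values shown sit. Going by these compounds, whether going from ethoxy to methoxy changes cytotoxicity at all stays open.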